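Methyl-to-hydrogen on the aryl oxygen in two bitter-taste antagonists

The source may hold more compounds than are shown below. What is called first, only, known or untested is meant among the compounds shown, and "the series" means these compounds.

Measured compounds:
compound 1, `COc1ccc(C(=O)Nc2cnn(Cc3c(C)noc3C)c2)cc1`, 700 nM
compound 2, `Cc1noc(C)c1Cn1cc(NC(=O)c2ccc(O)cc2)cn1`, 500 nM
compound 3, `COc1ccccc1CN1CC(=O)N(c2cnn(Cc3c(C)noc3C)c2)C1=O`, 100 nM

In a functional assay on cells for antagonist activity at taste receptor type 2 member 8 (Homo sapiens), read by FLIPR and calcium flux, with a stated time of 100 s (a lower number here means a stronger inhibitor, a higher number a weaker inhibitor), compound 1 gives 700 nM and compound 2 gives 500 nM. The change between them, (hydrogen in place of methyl on an oxygen on an aromatic ring), produced a 1.4-fold lower number from compound 1 to compound 2 (0.15 log units; within the scatter). Compound 3, with `COc1ccccc1CN1CC(=O)N(c2cnn(Cc3c(C)noc3C)c2)C1=O`, gives 100 nM in this assay; how its core differs from that of compound 1 is not broken down here. Compound 4, `Cc1noc(C)c1Cn1cc(N2C(=O)CN(Cc3ccccc3O)C2=O)cn1`, carries the same change as compound 3 does, namely (hydrogen in place of methyl on an oxygen on an aromatic ring); cut one bond further out it reads 2-methoxybenzyl to 2-hydroxybenzyl, whereas the earlier one reads 4-methoxyphenyl to 4-hydroxyphenyl, so it is the same kind of change. Because a 1.4-fold lower number from compound 1 to compound 2 (0.15 log units; within the scatter) stayed within the scatter, compound 4 is expected to show a 1.3-fold lower number from compound 3 to compound 4 (0.10 log units; within the scatter). Compound 4 is therefore estimated at 80 nM, between 30 nM and 250 nM.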

Compound 4, half-maximal inhibitory concentration: 100 nM
Compound 4: the middle estimate sits 1.3-fold (0.10 log units) below what was measured, and the stated range covers the measured number.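

Hydrogen in place of methyl on the oxygen on the aromatic ring produced no change at the digits printed from compound 3 to compound 4 (within the scatter) in this assay, and set beside the earlier step, the change carries across the two cores without a difference that can be told apart: the same change on two cores in this assay, a 1.4-fold lower number (0.15 log units; within the scatter) from compound 1 to compound 2 and no change at the digits printed (within the scatter) from compound 3 to compound 4, 1.4-fold (0.15 log units) apart, within the scatter of two such steps.

This shows that swapping methoxy for hydroxy left the number within the scatter on both cores. It does not show how the change would behave on any other core, and two steps this small cannot show whether a larger effect would carry over.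

The compounds shown leave open what a longer chain on that oxygen would do. They also leave open what an amine or a carboxylic acid in place of the hydroxy would do in this assay.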